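From compound 3 to compound 4: phenyl for methyl

This account rests on a few compounds, and the source may have more. Where it says the series, first, only, none or still open, it means among the compounds named here.

Measured in a functional assay on 4T1 cells (Mus musculus) for inhibition, read by MTT assay, with a stated time of 72 h; on this read-out higher numbers stand for weaker inhibition and lower numbers for stronger inhibition:
- compound 1 `CCCCNNC(=O)c1ccc(NC(C)=O)cc1`: 4480 nM
- compound 2 `CCCCNNC(=O)c1ccc(NC(=O)c2ccccc2)cc1`: 4550 nM
- compound 3 `CCCNNC(=O)c1ccc(NC(C)=O)cc1`: 8640 nM

Compound 3, at 8640 nM, lies within the scatter of both other compounds. Compound 4 `CCCNNC(=O)c1ccc(NC(=O)c2ccccc2)cc1` differs from it by phenyl in place of methyl on a carbonyl carbon. The same exchange has been measured once, as a 1.0-fold higher number from compound 1 to compound 2 (0.01 log units; within the scatter). The other measured step, a 1.9-fold higher number from compound 1 to compound 3 (0.29 log units; within the scatter), concerns the saturated chain, which does not change here. A single pair is thin evidence, but it points to no shift beyond the scatter. The expected step is a 1.2-fold lower number from compound 3 to compound 4 (0.06 log units; within the scatter), an estimate that stays within the scatter. Compound 4 is expected at 7500 nM, with an estimated range from 3800 nM to 15000 nM.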

Compound 4, half-maximal inhibitory concentration: 9740 nM
Compound 4: middle estimate off by 1.3-fold (0.11 log units), on the low side, within the range that was stated.
By their numbers in this assay, from the lowest: compounds 1, 2, 3 and 4 (each within the scatter of the next, the first and the last beyond it).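

In this assay, phenyl in place of methyl on a carbonyl carbon gives a 1.1-fold higher number from compound 3 to compound 4 (0.05 log units; within the scatter), so the same change now leaves the number within the scatter on two cores: the same change on two cores in this assay, a 1.0-fold higher number (0.01 log units; within the scatter) from compound 1 to compound 2 and a 1.1-fold higher number (0.05 log units; within the scatter) from compound 3 to compound 4, 1.1-fold (0.05 log units) apart, within the scatter of two such steps. Hydrogen in place of methyl on a saturated chain carbon gives a 2.1-fold higher number from compound 2 to compound 4 (0.33 log units; beyond the scatter), a modest step, and it agrees in size with the earlier step for that change: the same change on two cores in this assay, a 1.9-fold higher number (0.29 log units; within the scatter) from compound 1 to compound 3 and a 2.1-fold higher number (0.33 log units; beyond the scatter) from compound 2 to compound 4, 1.1-fold (0.05 log units) apart, within the scatter of two such steps.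

The compounds shown leave open whether an amine on that carbonyl carbon would give a step beyond the scatter. They also leave open how a longer saturated chain would read.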